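Replacing the 1-hydroxypropyl group on the shared core: compound 4

The source may report more compounds than this note shows. Statements on the series, on what has been measured and on what is new or still open speak of the compounds shown alone.

Compound 1 `CCn1c(CNc2ccccc2)nnc1SCc1nc2cc(F)ccc2o1`: in an assay on isolated protein for inhibition of long-chain fatty acid transport protein 1 (Homo sapiens) (a higher number here means a weaker inhibitor, a lower number a stronger inhibitor), compound 1 gives > 1000 nM, a limit.
Compound 2 `CCn1c(CNc2ccccc2)nnc1SCc1nc2cc(C)ccc2o1`: in this assay compound 2 gives > 1000 nM, a limit.
Compound 3 `CCC(O)c1ccc2oc(CSc3nnc(CNc4ccccc4)n3CC)nc2c1`: in this assay compound 3 gives > 1000 nM, a limit.

Compound 3 stands at the limit of this assay, as do the other two values shown (the limit of > 1000 nM in this assay, at which 3 of the 3 values shown sit). Compound 4 `CC/C(=N/O)c1ccc2oc(CSc3nnc(CNc4ccccc4)n3CC)nc2c1` differs from compound 3 by a group of 5 heavy atoms (3 carbon, 1 nitrogen, 1 oxygen; no ring) in place of a group of 4 heavy atoms (3 carbon, 1 oxygen; no ring), on an aromatic carbon, on a six-membered aromatic ring of carbon only that is part of a fused system of two rings. The steps that reach compound 3, a step that the two limits leave unreadable from compound 1 to compound 3 and a step that the two limits leave unreadable from compound 2 to compound 3, are both unreadable, so no direction can be taken from them. Compound 4 is therefore expected to sit near the same limit, with a step that the limit leaves unreadable from compound 3 to compound 4 as the estimated step, and 3000 nM (800 nM to 15000 nM) as the expected value.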

Compound 4, half-maximal inhibitory concentration: 260 nM
For compound 4 the middle estimate is 12-fold (1.06 log units) above the measured one; measured number below the stated range.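

In this assay this position on the shared core proves responsive to its substituent, with an at least 3.8-fold lower number from compound 3 to compound 4 (0.58 log units; beyond the scatter), an at least 3.8-fold lower number from compound 2 to compound 4 (0.58 log units; beyond the scatter) and an at least 3.8-fold lower number from compound 1 to compound 4 (0.58 log units; beyond the scatter). All three steps are open-ended, and the steps among compounds 1, 2 and 3 cannot be read. Compound 4 is the only compound shown that lies off the limit: the limit of > 1000 nM in this assay, at which 3 of the 4 values shown sit.

Going by these compounds, the full size of the gain remains open, as does which feature of the entering group carries it. On these data alone, how a ketone, an amine or a longer chain at this position would read also remains open.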